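The source may report more compounds than this note shows. Statements on the series, on what has been measured and on what is new or still open speak of the compounds shown alone.

Measured compounds:
compound 1, `CCCC#Cc1cc([C@@H]2O[C@H](CO)[C@@H](O)[C@H]2O)n2ncnc(N)c12`, 40 nM
compound 2, `Nc1ncnn2c([C@@H]3O[C@H](CO)[C@@H](O)[C@H]3O)cc(C#CC3CC3)c12`, 30 nM
compound 3, `Nc1ncnn2c([C@@H]3O[C@H](CO)[C@@H](O)[C@H]3O)cc(-c3ccc(Cl)cc3)c12`, 32600 nM

The three compounds share one core and differ only in the group carried on one aromatic carbon of the five-membered ring. In a functional assay on LN-229 cells (Homo sapiens) for antiproliferative activity, with a stated time of 72 h (a lower number here means a stronger inhibitor, a higher number a weaker inhibitor), compound 2 gives 30 nM, the lowest of the three numbers, though its difference from compound 1 is a 1.3-fold lower number from compound 1 to compound 2 (0.12 log units; within the scatter) and so not a real separation. Compound 3, with its 4-chlorophenyl, stands far apart: a 1100-fold higher number from compound 2 to compound 3 (3.04 log units; beyond the scatter), and likewise an 820-fold higher number from compound 1 to compound 3 (2.91 log units; beyond the scatter).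

Compound 4 is `COc1ccc(-c2cc([C@@H]3O[C@H](CO)[C@@H](O)[C@H]3O)n3ncnc(N)c23)cc1`. It is related to compound 2 by 4-methoxyphenyl in place of 2-cyclopropylethynyl on an aromatic carbon. Going by the values given here, the step that bears most directly on this change is the one from compound 2 to compound 3, where an aryl ring likewise replaced the triple-bonded group and the number rose by a very large margin. Among the compounds with values here, the change to compound 4 differs from that step only in the substituent on the entering ring, a methoxy group rather than a chlorine; nothing among the measured compounds tells how that difference matters, so the step to compound 4 is expected to be of a similar size and in the same direction, an 830-fold higher number from compound 2 to compound 4 (2.92 log units; beyond the scatter). For compound 4 the estimate in this assay is therefore 25000 nM, with a range from 6000 nM to 90000 nM.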

Compound 4, half-maximal inhibitory concentration: 40300 nM
Compound 4: the middle estimate sits 1.6-fold (0.21 log units) below what was measured, within the range that was stated.
By their numbers in this assay, from the lowest: compounds 2 and 1 (each within the scatter of the next); then compounds 3 and 4 (each within the scatter of the next).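

In this assay, the group on the entering ring makes no separable difference here: methoxy in place of chloro on the aromatic carbon gives a 1.2-fold higher number from compound 3 to compound 4 (0.09 log units; within the scatter) and leaves the two aryl compounds indistinguishable. Going by these compounds alone, the large rise is therefore not peculiar to the 4-chlorophenyl, for the 4-methoxyphenyl gives a 1300-fold higher number from compound 2 to compound 4 (3.13 log units; beyond the scatter) when it replaces 2-cyclopropylethynyl and a 1000-fold higher number from compound 1 to compound 4 (3.00 log units; beyond the scatter) when it replaces pent-1-yn-1-yl, so that at this aromatic carbon of the five-membered ring the four compounds fall into two pairs, the two with a triple bond and the two with a para-free description of simply a substituted phenyl ring, with no compound going against that split. Nothing measured in this set gives a reason for the gap between the two pairs.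

The compounds shown leave open whether the gap follows from the triple bond or from the directly attached aryl ring, a question that a saturated chain such as pentyl or a phenylethynyl group on this carbon would bear on. Also open, going by these compounds, is whether a phenyl ring carrying an amine or a carboxylic acid would stay with the aryl pair.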